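This account rests on a few compounds, and the source may have more. Where it says the series, first, only, none or still open, it means among the compounds named here.

Three compounds that share a catechol bearing a nitro group set the scene. Compound 1 `CC(=O)N1N=C(c2cc(O)c(O)c([N+](=O)[O-])c2)CC1c1ccc(C#N)cc1` gives 76600 nM in an assay on isolated protein for inhibition of Amine oxidase [flavin-containing] A (Homo sapiens), read by fluorescence; a higher number here means a weaker inhibitor, a lower number a stronger inhibitor. Compound 2 `CC(=O)N1N=C(c2cc(O)c(O)c([N+](=O)[O-])c2)CC1c1ccoc1` gives 90900 nM in this assay, and compound 3 `O=C(/C=C/c1ccco1)c1cc(O)c(O)c([N+](=O)[O-])c1`, which carries the same catechol on an open chain, gives 60500 nM. All three numbers lie within the scatter of one another, so compound 2 sits alongside the others rather than apart from them.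

Compound 4 `CC(=O)N1N=C(c2cc(O)c(O)c([N+](=O)[O-])c2)CC1c1cccc(O)c1` differs from compound 2 in one place: 3-hydroxyphenyl in place of furan-3-yl on a saturated ring carbon. Among the measured compounds shown here, the one measured step that bears on this, a 1.2-fold higher number from compound 1 to compound 2 (0.07 log units; within the scatter), also swapped the group on that saturated ring carbon and stayed within the scatter. The step to compound 4 is therefore expected to be a 1.1-fold lower number from compound 2 to compound 4 (0.06 log units; within the scatter), with no move beyond the scatter. Compound 4 is estimated at 80000 nM, between 35000 nM and 180000 nM.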

Compound 4, half-maximal inhibitory concentration: 87000 nM
Beside the measured number, compound 4's estimate is 1.1-fold (0.04 log units) below it; the measured number falls inside the stated range.
By their numbers in this assay, from the lowest: compounds 3, 1, 4 and 2 (each within the scatter of the next).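

At this saturated ring carbon, 3-hydroxyphenyl adds a hydrogen-bond donor that furan-3-yl lacks, yet this assay gives a 1.0-fold lower number from compound 2 to compound 4 (0.02 log units; within the scatter) and also a 1.1-fold higher number from compound 1 to compound 4 (0.06 log units; within the scatter). Among compounds 1, 2 and 4, neither the change of ring size nor the added donor moves the number beyond the scatter. No measurement shown here explains this. From the compounds shown here alone, whether an amine, a carboxylic acid or a longer chain at this carbon would shift the number stays open. So does whether changing the acetyl group on the neighbouring ring nitrogen would matter more.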